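This account rests on a few compounds, and the source may have more. Where it says the series, first, only, none or still open, it means among the compounds named here.

The measured compounds in an ADME assay on liver (Mesocricetus auratus) for metabolic stability, using microsomes (a lower number here means slower removal, a higher number faster removal of the compound), are these. Compound 1 `O=C(Nc1cc(-c2ccccn2)n[nH]1)N1CCC(c2ccc(Cl)cc2)CC1` gives 43.8 mL.min-1.g-1. Compound 3 `O=C(Nc1cc(-c2ccccn2)n[nH]1)N1CCC(Oc2ccccn2)CC1` gives 67.3 mL.min-1.g-1. Compound 2 `O=C(Nc1[nH]nc(-c2ccccn2)c1C1CC1)c1c(Cl)cccc1Cl` gives > 100 mL.min-1.g-1, which is a limit of this assay and not a number.

Compound 2 therefore stands at the limit of > 100 mL.min-1.g-1 in this assay, at which 1 of the 3 values shown sits, and only a limit is known for it, with no number to compare against the other two. Among the measured compounds shown here, the single measured step, a 1.5-fold higher number from compound 1 to compound 3 (0.19 log units; within the scatter), alters a group on a saturated ring carbon of a core that compound 2 does not share, and it does not touch the carbonyl carbon where the change to compound 4 sits. Compound 4 `COc1ccc(C(=O)Nc2[nH]nc(-c3ccccn3)c2C2CC2)cc1` differs from compound 2 in one place: 4-methoxyphenyl in place of 2,6-dichlorophenyl on a carbonyl carbon. For the measured compounds named here, no measured step bears on this change, so the data give no direction for it. The step from compound 2 is expected to be an at least 1.2-fold lower number from compound 2 to compound 4 (0.09 log units; that floor lies within the scatter). For compound 4 in this assay the estimated value is 80 mL.min-1.g-1, expected to lie between 30 mL.min-1.g-1 and 200 mL.min-1.g-1.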

Compound 4, intrinsic clearance in microsomes: > 100 mL.min-1.g-1
Compound 4 gave a limit, no number; the forecaster's own chance of this, stated with the estimate: 45%; at least 1.2-fold (0.09 log units) between middle value and limit.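

Among the compounds shown here, compound 2 and compound 4 both stand at a limit of this assay and not at a number, so no step between them can be read: the limit of > 100 mL.min-1.g-1 in this assay, at which 2 of the 4 values shown sit.

The compounds shown leave open whether 4-methoxyphenyl in place of 2,6-dichlorophenyl on a carbonyl carbon changes the read-out at all, and in which direction.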